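This account rests on a few compounds, and the source may have more. Where it says the series, first, only, none or still open, it means among the compounds named here.

The measured compounds, each tested in a functional assay on K562 cells (Homo sapiens) for cytotoxicity, with a stated time of 72 h; on this read-out lower numbers stand for stronger inhibition and higher numbers for weaker inhibition:

Compound 1, `C[C@H](NC(=O)c1cc(Cl)ccc1O)C(=O)Nc1ccc(C(F)(F)F)cc1`: in this assay compound 1 gives > 12500 nM, which is a limit of the assay and not a number.
Compound 2, `C[C@H](NC(=O)c1cc(Cl)ccc1O)C(=O)Nc1cccc(Cl)c1`: in this assay compound 2 gives > 10000 nM, again a limit of the assay.
Compound 3, `Cc1ccc(NC(=O)[C@H](CC2CCCC2)NC(=O)c2cc(Cl)ccc2O)cc1`: in this assay compound 3 gives > 10000 nM, also a limit of the assay.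

Compound 3 therefore stands at a limit rather than at a number, and so do the other two; the only marks to go by are the limit of > 10000 nM in this assay, at which 2 of the 3 values shown sit, and (the limit of > 12500 nM in this assay, at which 1 of the 3 values shown sits). Among the measured compounds shown here, no step between measured compounds can be read from these, since none of them gives a true value.

Compound 4 is `Cc1ccc(NC(=O)[C@H](C)NC(=O)c2cc(Cl)ccc2O)cc1`. It differs from compound 3 by hydrogen in place of cyclopentyl on a saturated chain carbon, two bonds along the chain from an amide-type nitrogen and a carbonyl carbon. With nothing but limits around it, the expectation for the step from compound 3 to compound 4 in this assay is none beyond the scatter, that is a step that the limit leaves unreadable from compound 3 to compound 4, and compound 4 is most likely to be reported as a limit as well. Compound 4 is estimated at 15000 nM, with a range from 5000 nM to 50000 nM.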

Compound 4, half-maximal inhibitory concentration: > 10000 nM
Compound 4 gave a limit, no number; the forecaster's own chance of this, stated with the estimate: 85%; the middle value lies beyond the limit too.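

Among the compounds shown here, compound 4, like compound 1, compound 2 and compound 3, gives only a limit of the assay and not a number, so no step between these compounds can be read. The compounds shown leave open which change, if any, would bring a true number in this assay.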